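The compounds below may be only part of what the source reports. "The series", "measured", "known", "first", "only" and "open" are said of these compounds alone.

Measured in a functional assay on A549 cells (Homo sapiens) for inhibition, read by MTT assay, with a stated time of 48 h, tested at 10 uM (a higher number here means more inhibition of growth at the concentration tested, a lower number less inhibition of growth), the three known compounds read as follows: compound 1 `O=C(/C=C/c1ccc(OCc2cn(Cc3ccc(Br)cc3)nn2)cc1)c1ccc(Br)cc1` gives 27%; compound 2 `O=C(/C=C/c1ccc(OCc2cn(Cc3ccccc3Br)nn2)cc1)c1ccc([N+](=O)[O-])cc1` gives 42%; compound 3 `O=C(/C=C/c1ccc(OCc2cn(Cc3cccc(Br)c3)nn2)cc1)c1ccc([N+](=O)[O-])cc1` gives 28%.

Compound 3 stands second of the three. Its number and that of compound 1 lie within the scatter of each other, so no order between them can be read. Against compound 2 the only single-point step is a number 14 percentage points lower from compound 2 to compound 3 (beyond the scatter).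

Compound 4 `O=C(/C=C/c1ccc(OCc2cn(Cc3ccc(Br)cc3)nn2)cc1)c1ccc([N+](=O)[O-])cc1` differs from compound 3 by 4-bromophenyl in place of 3-bromophenyl on a saturated chain carbon bound to an aromatic nitrogen. Going by the values given here, no measured pair covers this exact move; the one step that bears on it, a number 14 percentage points lower from compound 2 to compound 3 (beyond the scatter), shifts the bromine on the same ring and is modest. Compound 1 carries the 4-bromophenyl at this place but differs elsewhere as well, and compound 1 gives 27% where compound 3 gives 28%, a difference within the scatter. The step of a number 1 percentage points lower from compound 3 to compound 4 (within the scatter) is therefore expected to stay within the scatter. Compound 4 is estimated at 27%, in the range 15% to 40%.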

Compound 4, percent growth inhibition at one concentration: 18%
Compound 4: middle estimate off by 9 percentage points, on the high side; low and high end bracket the measured number.
By their numbers in this assay, from the lowest: compounds 4, 1 and 3 (each within the scatter of the next); then compound 2.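

In this assay, 4-bromophenyl in place of 2-bromophenyl gives a number 24 percentage points lower from compound 2 to compound 4 (beyond the scatter), so compound 2 now stands apart from both other bromine placements at this position. Those two placements cannot be ordered, as the result is a number 10 percentage points lower from compound 3 to compound 4 (within the scatter). With 4-bromophenyl held fixed, nitro in place of bromo on an aromatic carbon also gives no readable change, at a number 9 percentage points lower from compound 1 to compound 4 (within the scatter). Nothing available explains the higher number of compound 2. As far as these compounds go, whether an amine or a carboxylic acid in place of the bromine, or a longer chain in place of the benzyl link, would keep that number remains open.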